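The compounds below may be only part of what the source reports. "The series", "measured", "known", "first", "only" and "open" are said of these compounds alone.

Compound 1 `Nc1nc(-c2ccc(Cl)cc2)c(CC(=O)O)s1` belongs to a small set of acids built on one shared core, in which only a single substituent on the five-membered aromatic ring is varied. In an in vitro functional assay on HEK285-7 cells for antagonist activity at prostaglandin D2 receptor 2 (Homo sapiens), read by BRET and beta-arrestin recruitment (on this read-out lower numbers stand for smaller maximal responses and higher numbers for larger maximal responses), compound 1 gives 50%. Compound 2 `O=C(O)Cc1sc(NC(=O)c2ccccc2)nc1-c1ccc(Cl)cc1` gives 50% and compound 3 `O=C(O)Cc1sc(C(Cc2ccccc2)c2ccccc2)nc1-c1ccc(Cl)cc1` gives 50%, so compound 1 stands level with both of them at the digits shown; the values of compound 1 and compound 3 sit at the same figure without a computed step between them.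

Compound 4 `Cc1nc(-c2ccc(Cl)cc2)c(CC(=O)O)s1` differs from compound 1 in one place: methyl in place of amino on an aromatic carbon. Among the compounds with values here, the one measured step that bears on this position is the one from compound 1 to compound 2, where a benzoyl group in place of hydrogen on the nitrogen gave no change at the digits printed from compound 1 to compound 2 (within the scatter). The values of compound 1 and compound 3 likewise show the same figure although compound 3 carries a carbon-linked group of many heavy atoms at that position. Nothing in the measured set points to a shift in this assay when the amino group is exchanged for methyl, so no step beyond the scatter is expected for compound 4, no change at the digits printed from compound 1 to compound 4 (within the scatter). Compound 4 is therefore estimated to reach 50%, with a range from 35% to 65%.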

Compound 4, largest response reached (reported as efficacy), in percent of the reference or control that the assay uses: 50%
For compound 4 middle estimate and measured number coincide at the digits printed; measured number inside the range.
By their numbers in this assay, from the lowest: compounds 1, 2, 3 and 4 (each within the scatter of the next).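

In this assay, methyl in place of amino on the aromatic carbon gave no change at the digits printed from compound 1 to compound 4 (within the scatter), although the hydrogen-bond donor and the hydrogen-bond acceptor counted for amino leave and methyl brings neither. The earlier step, no change at the digits printed from compound 1 to compound 2 (within the scatter), kept a nitrogen on this ring carbon, so only the new pair shows that, for these two groups, the maximal response stays within the scatter when that nitrogen itself is gone. No measurement is at hand that would account for this outcome.

The compounds shown include no change at this position that moves the read-out beyond the scatter, so it remains open whether an ethyl, a methoxy or a dimethylamino group on this aromatic carbon would do so. Going by these compounds, it also remains open how the maximal response would answer to a change elsewhere on the core, such as a carboxylic acid directly on the ring in place of the carboxymethyl group, or a longer chain between the ring and the acid.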